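Adenosine A3 binding: removal of the ring hydroxy in compound 2

The compounds below may be only part of what the source reports. "The series", "measured", "known", "first", "only" and "open" are said of these compounds alone.

Measured compounds in this part of the series:
compound 1 `CCNC(=O)OC[C@]1(O)CO[C@@H](n2cnc3c(N)ncnc32)[C@@H]1O` gives 6%
compound 2 `Nc1ncnc2c1ncn2[C@@H]1OC[C@@](O)(CO)[C@H]1O` gives 10%

Both numbers come from an assay on CHO cells for displacement of a labelled ligand from adenosine receptor A3 (Homo sapiens), tested at 10 uM; on this read-out lower numbers stand for less inhibition and higher numbers for more inhibition at the one concentration tested (going by the name of the read-out). Compound 2 is the reference point for the next step; against compound 1 the step of a number 4 percentage points higher from compound 1 to compound 2 (within the scatter) is within the scatter, so the two compounds read alike in this assay and neither can be placed above the other.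

Compound 3 `Nc1ncnc2c1ncn2[C@@H]1OC[C@H](CO)[C@H]1O` has not yet been measured. It differs from compound 2 as follows: hydrogen in place of hydroxy on a saturated ring carbon.

Going by the values given here, no measured step concerns a hydroxy group on a saturated ring carbon; the only step at hand, a number 4 percentage points higher from compound 1 to compound 2 (within the scatter), concerns a group on an oxygen on a saturated carbon and is itself within the scatter. Among the compounds with values here, there is therefore no measured precedent for the change to compound 3, and the two compounds measured so far both sit at low inhibition in this assay. On that basis compound 3 is expected to stay close to compound 2, with a step of a number 2 percentage points lower from compound 2 to compound 3 (within the scatter) that is estimated to lie within the scatter. The estimate for compound 3 in this assay is 8%, with a range from 0% to 25%.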

Compound 3, a percentage reported as inhibition, at one concentration (the size of the read-out at that concentration, not a potency): 32%
Compound 3: the middle estimate sits 24 percentage points below what was measured; the measured number lies above the stated range.
By their numbers in this assay, from the lowest: compounds 1 and 2 (each within the scatter of the next); then compound 3.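

Going by these compounds alone, replacing the hydroxy on the saturated ring carbon with hydrogen gives, in this assay, a number 22 percentage points higher from compound 2 to compound 3 (beyond the scatter) and is the first change in this part of the series to lie beyond the scatter, whereas the earlier step, a number 4 percentage points higher from compound 1 to compound 2 (within the scatter) on the group on an oxygen, could not be read as a difference. This ring carbon is therefore a place where the read-out responds, and the hydroxy there is not required for the inhibition seen, since compound 3 reads higher without it. Nothing measured here bears on the reason for this rise.

Still open, from the compounds shown here alone, is whether the gain belongs to hydrogen alone at this carbon or would also appear with a fluorine, a methoxy or an amine there, and whether an ethylcarbamoyl group on the oxygen would read the same once the ring hydroxy is gone. Since this assay reports the size of the read-out at one concentration and not a potency, how strongly compound 3 binds also remains undefined.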